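Two Aminothiophenes Measured, a Nitro Analogue Awaiting Its Number

The compounds below may be only part of what the source reports. "The series", "measured", "known", "first", "only" and "open" are said of these compounds alone.

The account concerns three compounds sharing one core. Compound 1 `CCOC(=O)c1c(-c2cccc(C(F)(F)F)c2)csc1N` is the smaller of the two measured; in an assay on CHO-K1 cells for displacement of a labelled ligand from adenosine receptor A1 (Homo sapiens), tested at 10 uM (on this read-out lower numbers stand for less inhibition and higher numbers for more inhibition at the one concentration tested (going by the name of the read-out)), compound 1 gives 93%. Compound 2 `Nc1sc(-c2ccccc2)c(-c2cccc(C(F)(F)F)c2)c1C(=O)c1ccccc1` carries a phenyl and a benzoyl on the core, and in this assay compound 2 gives 82.4%, the lower of the two measured numbers, a gap to compound 1 that lies beyond the usual scatter. Compound 3 `Nc1sc(-c2ccc([N+](=O)[O-])cc2)c(-c2cccc(C(F)(F)F)c2)c1C(=O)c1ccccc1` is not yet measured. It differs from compound 2 in one place: nitro in place of hydrogen on an aromatic carbon, the change sitting on an aromatic carbon of a six-membered aromatic ring of carbon only, para to a large group. For the measured compounds named here, no measured pair shows such a change, so nothing in the data fixes its size or direction. The step from compound 2 to compound 3 in this assay is expected to be a number 2.4 percentage points lower from compound 2 to compound 3 (within the scatter), none beyond the scatter. Compound 3 is therefore estimated at 80%, with a range from 60% to 95%.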

Compound 3, a percentage reported as inhibition, at one concentration (the size of the read-out at that concentration, not a potency): 34.8%
Compound 3: the middle estimate sits 45.2 percentage points above what was measured, outside the stated range (below it).
By their numbers in this assay, from the lowest: compound 3; then compound 2; then compound 1.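

In this assay the change from phenyl to 4-nitrophenyl gives a number 47.6 percentage points lower from compound 2 to compound 3 (beyond the scatter), so this place, para to a large group, is not indifferent to what it carries, something compound 1 and compound 2 could not show. Nitro in place of hydrogen, a single added group with no ring, is enough on its own to produce this large step, though only this one pair speaks to it. Nothing shown here bears on the reason for the step.

On these data alone, whether the same step would follow from another group at this place, such as an amine, a carboxylic acid or a nitrile, remains open. So does whether nitro would have a step of similar size and direction on the smaller core of compound 1, which lacks the phenyl and the benzoyl.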